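Swapping methoxy for tert-butyl on the aryl substituent

A few compounds are considered here, and "the series" means these few. Any claim that something is new, unique, unknown or untested is made for them only; others in the source may bear on it.

Measured so far in an ADME assay on HepG2 cells (Homo sapiens) for cytotoxicity, read by luminescence, CellTiter-Glo and ATP content, with a stated time of 72 h; a higher number here means that more compound is needed for the effect, a lower number that less compound is needed:
Compound 1 `COc1ccc(-c2ccc3c(NCCCNCc4cccc(OC)c4O)ccnc3c2)cc1` gives 1600 nM.
Compound 2 `Fc1ccc(-c2ccc3c(NCCCNCc4ccco4)ccnc3c2)cc1` gives 7760 nM.
Compound 3 `COc1ccc(F)cc1CNCCCNc1ccnc2cc(Oc3ccc(F)cc3)ccc12` gives 6600 nM.

Compound 1 has the lowest of the three numbers in this assay; compound 3 sits beyond the scatter above it, and compound 2 further still. Compound 4 `COc1cccc(CNCCCNc2ccnc3cc(-c4ccc(C(C)(C)C)cc4)ccc23)c1O` differs from compound 1 by tert-butyl in place of methoxy on an aromatic carbon. Among the compounds with values here, no pair of measured compounds differing in one place is available to calibrate such a change, so the step from compound 1 to compound 4 in this assay is expected to be small, likely within the scatter, with no clear direction. Compound 4 is therefore estimated at 1300 nM, in a range from 450 nM to 4000 nM, which corresponds to an expected step of a 1.2-fold lower number from compound 1 to compound 4 (0.09 log units; within the scatter).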

Compound 4, half-maximal effective concentration: 690 nM
Beside the measured number, compound 4's estimate is 1.9-fold (0.28 log units) above it, within the range that was stated.
By their numbers in this assay, from the lowest: compound 4; then compound 1; then compounds 3 and 2 (each within the scatter of the next).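

In this assay, changing 4-methoxyphenyl to 4-(tert-butyl)phenyl gives a 2.3-fold lower number from compound 1 to compound 4 (0.37 log units; beyond the scatter) and so shows that the number responds to the group at this position of the aryl substituent. This is the only single-place step among the compounds shown, and it makes compound 4 the one with the lowest number of the four. Nothing measured here accounts for the shift.

Going by these compounds, it remains open whether a methyl, a chlorine or a dimethylamino group at this position would move the number the same way. On these data alone, it is also open whether the same change would hold with the other side chains, such as the furan-bearing one of compound 2.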